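The compounds below may be only part of what the source reports. "The series", "measured", "known", "first", "only" and "open" are said of these compounds alone.

Compound 1, whose structure is `CN1[C@@H]2c3[nH]c4ccccc4c3C[C@H]1[C@H](C#N)N1[C@@H](CN3C(=O)c4ccccc4C3=O)c3[nH]c4ccccc4c3C[C@@H]21`, sets the reference point here. In a functional assay on HCT-116 cells (Homo sapiens) for cytotoxicity, read by MTT assay, with a stated time of 72 h (on this read-out higher numbers stand for weaker inhibition and lower numbers for stronger inhibition), compound 1 gives 40 nM, the lowest number of the three measured compounds and therefore the strongest inhibition of the set. The two comparison compounds both replace the same group with an amide carrying a fused bicyclic aromatic ring. Compound 2, with the structure `CN1[C@@H]2c3[nH]c4ccccc4c3C[C@H]1[C@H](C#N)N1[C@@H](CNC(=O)c3cc4ccccc4s3)c3[nH]c4ccccc4c3C[C@@H]21`, gives 500 nM in this assay, and compound 3, with the structure `CN1[C@@H]2c3[nH]c4ccccc4c3C[C@H]1[C@H](C#N)N1[C@@H](CNC(=O)c3cc4ccccc4o3)c3[nH]c4ccccc4c3C[C@@H]21`, gives 330 nM. Both changes weaken inhibition clearly: there is a 13-fold higher number from compound 1 to compound 2 (1.10 log units; beyond the scatter) and an 8.3-fold higher number from compound 1 to compound 3 (0.92 log units; beyond the scatter), while the exchange between the two bicyclic rings is only a 1.5-fold lower number from compound 2 to compound 3 (0.18 log units; within the scatter).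

Compound 4, with the structure `CN1[C@@H]2c3[nH]c4ccccc4c3C[C@H]1[C@H](C#N)N1[C@@H](CNC(=O)c3cc4ccccc4[nH]3)c3[nH]c4ccccc4c3C[C@@H]21`, makes the same kind of change as compounds 2 and 3, but with an indole ring. Relative to compound 1 the change is a group of 12 heavy atoms (9 carbon, 2 nitrogen, 1 oxygen; one five-membered aromatic ring with 1 hetero atom, one six-membered aromatic ring of carbon only) in place of a group of 11 heavy atoms (8 carbon, 1 nitrogen, 2 oxygen; one five-membered non-aromatic ring with 1 hetero atom, one six-membered aromatic ring of carbon only), on a saturated chain carbon bound to a saturated ring carbon. Because the closely related steps a 13-fold higher number from compound 1 to compound 2 (1.10 log units; beyond the scatter) and an 8.3-fold higher number from compound 1 to compound 3 (0.92 log units; beyond the scatter) were both large losses, a similar loss is expected for compound 4 in this assay. The number for compound 4 is therefore estimated at 300 nM, with a likely range from 100 nM to 1000 nM. That estimate corresponds to an expected 7.5-fold higher number from compound 1 to compound 4 (0.88 log units; beyond the scatter).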

Compound 4, half-maximal inhibitory concentration: 880 nM
Compound 4: the middle estimate sits 2.9-fold (0.47 log units) below what was measured; low and high end bracket the measured number.
By their numbers in this assay, from the lowest: compound 1; then compounds 3, 2 and 4 (each within the scatter of the next, the first and the last beyond it).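

In this assay, the indole amide of compound 4 shows the same clear loss against the phthalimide-type group of compound 1 (a 22-fold higher number from compound 1 to compound 4 (1.34 log units; beyond the scatter)), so all three amides on this saturated chain carbon give weaker inhibition than compound 1. What the earlier pair could not show is that the ring on the carbonyl carbon can matter: benzothiophene and benzofuran could not be told apart, but 1H-indol-2-yl in place of 1-benzofuran-2-yl does give a separable change (a 2.7-fold higher number from compound 3 to compound 4 (0.43 log units; beyond the scatter)). The effect of the ring is still small and not a clean ranking, since 1H-indol-2-yl in place of 1-benzothiophen-2-yl stays within the scatter (a 1.8-fold higher number from compound 2 to compound 4 (0.25 log units; within the scatter)).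

Going by these compounds, it remains open whether the loss comes from the amide link or from the fused ring system it carries, and a simple acetyl amide or a free primary amine on the same chain carbon would help to separate these two parts. The data also offer no measurement that accounts for the loss or for the difference among the rings.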